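From oxolan-3-yl to oxolan-2-yl: an expected permeability

The source may report more compounds than this note shows. Statements on the series, on what has been measured and on what is new or still open speak of the compounds shown alone.

- Compound 1 (`Cc1cc(C)c(CN2CCc3c(Cl)cc([C@H](CO)[C@H]4CCOC4)c(Cl)c3C2=O)c(=O)[nH]1`) gives 2.9 10^-6 cm/s
- Compound 2 (`COC(c1cc(Cl)c2c(c1Cl)C(=O)N(Cc1c(C)cc(C)[nH]c1=O)CC2)C1CCS(=O)(=O)CC1`) gives 6.3 10^-6 cm/s; 5.7 10^-6 cm/s (2 entries)

Among the measured compounds shown here, in an ADME assay on MDCK cells (Canis lupus familiaris) for permeability, read by LC-MS, with a stated time of 90 min, tested at 2 uM (a higher number here means that the compound crosses the layer faster, a lower number that the compound crosses the layer more slowly), compound 1 stands at 2.9 10^-6 cm/s as its only number, and one further entry for it carries no single number. Repeat entries exist for compound 2 (the several entries of compound 2 in this assay, 6.3 10^-6 cm/s; 5.7 10^-6 cm/s (2 entries)) and show how closely repeats agree here. For the measured compounds named here, compound 2 differs from compound 1 in more than one place, so no measured step guides what follows.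

Compound 3 (`Cc1cc(C)c(CN2CCc3c(Cl)cc([C@H](CO)[C@@H]4CCCO4)c(Cl)c3C2=O)c(=O)[nH]1`) has the same atoms as compound 1, joined differently (oxolan-2-yl in place of oxolan-3-yl on a saturated chain carbon bound to an aromatic carbon and a saturated chain carbon): oxolan-2-yl in place of oxolan-3-yl on a saturated chain carbon bound to an aromatic carbon and a saturated chain carbon. Going by the values given here, with no measured step to draw on, the expectation rests on compound 1 at 2.9 10^-6 cm/s alone, and no shift beyond the scatter in this assay is expected, in either direction. The expected change is a 1.1-fold higher number from compound 1 to compound 3 (0.04 log units; within the scatter) and is only an estimate. For compound 3 the estimated value is 3.2 10^-6 cm/s within an expected range from 1.4 10^-6 cm/s to 7.5 10^-6 cm/s once measured.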

Compound 3, apparent permeability: 14.6 10^-6 cm/s
Compound 3: the middle estimate sits 4.6-fold (0.66 log units) below what was measured; measured number outside the range, above it.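

In this assay, moving the attachment point of the ring, from oxolan-3-yl to oxolan-2-yl on a saturated chain carbon bound to an aromatic carbon and a saturated chain carbon, gives a 5.0-fold higher number from compound 1 to compound 3 (0.70 log units; beyond the scatter). The group that leaves and the group that enters have the same heavy atoms, the same ring size and the same hydrogen-bond donor and acceptor counts, so this read-out at this position depends on more than what those counts describe, which compound 1 alone could not show. A step of this size also stands well apart from the agreement between repeat readings, so it is not easily put down to noise in the measurement: the several entries of compound 2 in this assay, 6.3 10^-6 cm/s; 5.7 10^-6 cm/s (2 entries)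

This is a single pair, and it does not tell which feature of the change is responsible, or whether oxolan-2-yl with the opposite arrangement at its ring carbon would give a similar number. It also leaves open whether a ring carrying an amine in place of the oxygen, such as pyrrolidin-2-yl, would hold the higher number at this same place.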